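Taking the trifluoromethyl group off compound 1

This account rests on a few compounds, and the source may have more. Where it says the series, first, only, none or still open, it means among the compounds named here.

Values measured in (an ADME assay on Vero 76 cells (Chlorocebus sabaeus) for cytotoxicity, read by MTT assay, with a stated time of 96 h; on this read-out higher numbers stand for lower toxicity in this test and lower numbers for higher toxicity in this test):
compound 1 (`FC(F)(F)c1ccc(NCc2cn(-c3ccccc3)nc2-c2ccc(Br)cc2)cc1`) gives (28000 nM)
compound 2 (`FC(F)(F)c1ccc(NCc2cn(-c3ccccc3)nc2-c2ccc(C(F)(F)F)cc2)cc1`) gives (26000 nM)
compound 3 (`FC(F)(F)c1ccc(NCc2cn(-c3ccccc3)nc2-c2ccc(Cl)cc2)cc1`) gives (18000 nM)

Compound 1 stands level with compound 2 and compound 3. Its steps to them, (a 1.1-fold lower number from compound 1 to compound 2 (0.03 log units; within the scatter)) and (a 1.6-fold lower number from compound 1 to compound 3 (0.19 log units; within the scatter)), both lie within the scatter, as does (a 1.4-fold lower number from compound 2 to compound 3 (0.16 log units; within the scatter)), so the three values do not separate.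

Compound 4 (`Brc1ccc(-c2nn(-c3ccccc3)cc2CNc2ccccc2)cc1`) has not been measured yet. It differs from compound 1 by one change (hydrogen in place of trifluoromethyl on an aromatic carbon): hydrogen in place of trifluoromethyl on an aromatic carbon, para to a large group. The measured steps bear on this only indirectly. Among the measured compounds shown here, they exchange bromo, trifluoromethyl and chloro elsewhere in the molecule, while all three compounds keep the trifluoromethyl that leaves here, so no measured step removes it.

With steps as small as (a 1.6-fold lower number from compound 1 to compound 3 (0.19 log units; within the scatter)) among the measured compounds, a small step is expected in (this assay), perhaps towards a slightly higher number, though the data fix no firm direction. The estimated step is (a 1.3-fold higher number from compound 1 to compound 4 (0.10 log units; within the scatter)). For compound 4 the expected value is (35000 nM), with an estimated range from (15000 nM) to (85000 nM).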

Compound 4, half-maximal cytotoxic concentration: 52000 nM
The estimate for compound 4 lay 1.5-fold (0.17 log units) below the measured number, and the stated range covers the measured number.
By their numbers in this assay, from the lowest: compounds 3, 2, 1 and 4 (each within the scatter of the next, the first and the last beyond it).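

Among the compounds shown here, compound 4 is the first compound here in which the change touches this position, and in this assay going from 4-(trifluoromethyl)phenyl to phenyl gives a 1.9-fold higher number from compound 1 to compound 4 (0.27 log units; within the scatter). The earlier steps shown here only exchanged bromo, trifluoromethyl and chloro elsewhere in the molecule, so they could not show what happens when this trifluoromethyl is lost. This pair shows that, on this aromatic carbon, para to a large group, the whole trifluoromethyl can be replaced by hydrogen without the two compounds separating on this read-out, and no measurement at hand offers an explanation for that result.

The compounds shown leave open how a different group at this place, such as an amine, a carboxylic acid or a longer chain, would read in this assay. For the compounds shown here, they also leave open whether hydrogen in place of trifluoromethyl would read the same way with chloro or trifluoromethyl standing where compound 1 carries its bromo, as this single pair is the only one that carries the change.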